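Chloro on the pendant phenyl of compound 3

The source may report more compounds than this note shows. Statements on the series, on what has been measured and on what is new or still open speak of the compounds shown alone.

Compound 3 `Cc1cc(O)c(C(=O)/C=C/c2ccc(Cl)cc2)c(-c2ccccc2)c1C(=O)/C=C/c1ccc(Cl)cc1` is followed here toward compound 4 `Cc1cc(O)c(C(=O)/C=C/c2ccc(Cl)cc2)c(-c2ccc(Cl)cc2)c1C(=O)/C=C/c1ccc(Cl)cc1`. Three members of the series have been measured in a functional assay on MCF7 cells (Homo sapiens) for cytotoxicity, read by MTT assay, with a stated time of 24 h; a higher number here means a weaker inhibitor, a lower number a stronger inhibitor. Compound 1 `Cc1cc(O)c(C(=O)/C=C/c2ccccc2Cl)c(-c2ccc(Cl)cc2)c1C(=O)/C=C/c1ccccc1Cl` gives 30000 nM, compound 2 `Cc1cc(O)c(C(=O)/C=C/c2ccccc2)c(-c2ccc(Br)cc2)c1C(=O)/C=C/c1ccccc1` gives 10000 nM, and compound 3 gives 10000 nM. On these numbers compound 3 is level with compound 2 at the digits shown, the two together the lowest of the three, while compound 1 gives a higher number, beyond the scatter. Compound 4 carries the change (chloro in place of hydrogen on an aromatic carbon). Among the compounds with values here, no measured pair differs by this change alone, so nothing fixes its size directly. The step from compound 3 to compound 4 is expected to stay within the scatter, with at most a slight drift toward a higher number: a 1.3-fold higher number from compound 3 to compound 4 (0.11 log units; within the scatter). Compound 4 is therefore expected to give 13000 nM in this assay, within 5000 nM to 40000 nM.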

Compound 4, half-maximal inhibitory concentration: 28000 nM
Compound 4: middle estimate off by 2.2-fold (0.33 log units), on the low side, within the range that was stated.
By their numbers in this assay, from the lowest: compounds 2 and 3 (each within the scatter of the next); then compounds 4 and 1 (each within the scatter of the next).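

In this assay, within the data shown here, the change from phenyl to 4-chlorophenyl gives a 2.8-fold higher number from compound 3 to compound 4 (0.45 log units; beyond the scatter) as the first single-place step. A chloro at this position, para to a large group, therefore does not leave the number unchanged against the hydrogen of compound 3, and the shift is toward weaker inhibition. No measurement available here bears on the origin of this shift.

Still open, as far as these compounds go, is whether a methoxy, an amine or a carboxylic acid at the same position would move the number in the same direction. Also open, from the compounds shown here alone, is whether the chloro step holds when the other two aromatic rings carry no chloro.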